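A few compounds are considered here, and "the series" means these few. Any claim that something is new, unique, unknown or untested is made for them only; others in the source may bear on it.

Compound 2 `Nc1ccn(C2OC(CO)C(Br)C2O)c(=O)n1` gives 0.03 ug/mL in a functional assay on L5178Y cells (Mus musculus) for antiproliferative activity; a higher number here means a weaker inhibitor, a lower number a stronger inhibitor. Among the compounds with values here, this is the lowest of the three numbers known so far: compound 3 `Nc1nc(=O)n(C2OC(CO)C(Br)C2O)cc1F` gives 0.06 ug/mL, and compound 1 `Nc1nc(=O)n(C2OC(CO)C(I)C2O)cc1F` gives 0.08 ug/mL, which is beyond the scatter from compound 2, while compound 3 is not.

Compound 4 `Nc1ccn(C2OC(CO)C(I)C2O)c(=O)n1` differs from compound 2 at one position: iodo in place of bromo on a saturated ring carbon. The same exchange, run in the opposite direction, occurs between compound 1 and compound 3, where a 1.3-fold lower number from compound 1 to compound 3 (0.12 log units; within the scatter), a step inside the scatter. The other known step, a 2.0-fold higher number from compound 2 to compound 3 (0.30 log units; within the scatter), concerns a different position and does not bear on this change.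

Because the step of a 1.3-fold lower number from compound 1 to compound 3 (0.12 log units; within the scatter) stayed within the scatter, the move to compound 4 is expected to stay there too, with at most a slightly higher number. The estimate for compound 4 is 0.04 ug/mL, spanning 0.02 ug/mL to 0.08 ug/mL, meaning an expected 1.3-fold higher number from compound 2 to compound 4 (0.12 log units; within the scatter).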

Compound 4, concentration for 50% inhibition: 0.1 ug/mL
Estimate against measurement, compound 4: 2.5-fold (0.40 log units) below; the whole stated range lies below it.
By their numbers in this assay, from the lowest: compounds 2, 3, 1 and 4 (each within the scatter of the next, the first and the last beyond it).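

In this assay, the exchange between bromo and iodo on this saturated ring carbon now gives a step beyond the scatter, a 3.3-fold higher number from compound 2 to compound 4 (0.52 log units; beyond the scatter), which the same exchange on the core of compound 1 did not give. Hydrogen in place of fluoro on the aromatic carbon stays within the scatter on the iodo core, a 1.3-fold higher number from compound 1 to compound 4 (0.10 log units; within the scatter), and the two readings of that change agree: the same change on two cores in this assay, a 2.0-fold higher number (0.30 log units; within the scatter) from compound 2 to compound 3 and a 1.3-fold lower number (0.10 log units; within the scatter) from compound 4 to compound 1, 2.5-fold (0.40 log units) apart, within the scatter of two such steps. The halogen exchange thus looks larger on the core without fluoro, yet its two readings cannot be told apart: the same change on two cores in this assay, a 1.3-fold lower number (0.12 log units; within the scatter) from compound 1 to compound 3 and a 3.3-fold lower number (0.52 log units; beyond the scatter) from compound 4 to compound 2, 2.5-fold (0.40 log units) apart, within the scatter of two such steps.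

The compounds shown carry only bromo or iodo on this carbon, so what chloro, an amine or a methyl group would do there remains open. As far as these compounds go, it also remains open whether the halogen exchange truly depends on the core.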